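This account rests on a few compounds, and the source may have more. Where it says the series, first, only, none or still open, it means among the compounds named here.

Two compounds share one core and differ only in the group on one aromatic carbon. Compound 1 `COc1cccc2c1CCC2c1ncc[nH]1` carries a methoxy there, and in a functional assay on CHO cells for agonist activity at Alpha-1A adrenergic receptor (Homo sapiens), read by FLIPR and calcium flux (a higher number here means a larger maximal response, a lower number a smaller maximal response), compound 1 reaches 65%. Compound 2 `Cn1cc(-c2cccc3c2CCC3c2ncc[nH]2)cn1` carries a 1-methyl-1H-pyrazol-4-yl instead, and in this assay compound 2 reaches 12%, the lower of the two numbers. For the measured compounds named here, the only step measured so far, a number 53 percentage points lower from compound 1 to compound 2 (beyond the scatter), shows how much this one group can change the maximal response.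

Compound 3 `CNC(=O)c1cccc2c1CCC2c1ncc[nH]1` is not yet measured. It differs from compound 2 as follows: methylcarbamoyl in place of 1-methyl-1H-pyrazol-4-yl on an aromatic carbon. The group that enters is smaller than the one that leaves and brings a hydrogen-bond donor. Going by the values given here, the one known step bears on this change only indirectly, since neither compound carries a methylcarbamoyl, so the expectation is uncertain. The step from the methoxy of compound 1 to the 1-methyl-1H-pyrazol-4-yl of compound 2 was large and downward, so a change away from the 1-methyl-1H-pyrazol-4-yl is expected to move the number back upward, by a number 28 percentage points higher from compound 2 to compound 3 (beyond the scatter). For compound 3 the estimate in this assay is 40%, within a range from 15% to 70%.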

Compound 3, largest response reached (Emax), in percent of the reference or control that the assay uses: 59%
Beside the measured number, compound 3's estimate is 19 percentage points below it; the range from low to high includes it.
By their numbers in this assay, from the lowest: compound 2; then compounds 3 and 1 (each within the scatter of the next).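

Putting methylcarbamoyl in place of the 1-methyl-1H-pyrazol-4-yl gives a number 47 percentage points higher from compound 2 to compound 3 (beyond the scatter) and so shows that the small maximal response of compound 2 in this assay does not come from the shared core alone. Putting methylcarbamoyl in place of methoxy gives a number 6 percentage points lower from compound 1 to compound 3 (within the scatter) and so leaves these two groups indistinguishable in this measurement, even though they are different groups. Among the three groups shown on this aromatic carbon, only the 1-methyl-1H-pyrazol-4-yl stands apart from the other two.

Still open, going by these compounds, is how a carboxylic acid, an amine or a dimethylcarbamoyl group on this same carbon would behave in this assay, and whether the amide hydrogen of the methylcarbamoyl matters. No evidence is available on why the 1-methyl-1H-pyrazol-4-yl stands apart.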